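Series notes: compound 2 to compound 3, chlorophenyl variant

A few compounds are considered here, and "the series" means these few. Any claim that something is new, unique, unknown or untested is made for them only; others in the source may bear on it.

Compound 1 `Cc1ccccc1NNC(=O)c1cccc(NS(=O)(=O)c2cnc(O)nc2O)c1` and compound 2 `Cc1cccc(NNC(=O)c2cccc(NS(=O)(=O)c3cnc(O)nc3O)c2)c1` differ only in 3-methylphenyl in place of 2-methylphenyl on an amine nitrogen. In a functional assay on OVCAR-3 cells (Homo sapiens) for antiproliferative activity, read by MTT assay, with a stated time of 24 h (on this read-out lower numbers stand for stronger inhibition and higher numbers for weaker inhibition), compound 1 reaches only the limit > 20000 nM. In this assay compound 2 likewise reaches only the limit > 20000 nM. The step that the two limits leave unreadable from compound 1 to compound 2 is unreadable since both values sit at the limit of > 20000 nM in this assay, at which 2 of the 2 values shown sit. Compound 3 `O=C(NNc1ccccc1Cl)c1cccc(NS(=O)(=O)c2cnc(O)nc2O)c1` carries 2-chlorophenyl in place of 3-methylphenyl on an amine nitrogen. Among the compounds with values here, no measured step bears on this change; both values shown are limits. Compound 3 is expected to stay at the limit, an estimated step that the limit leaves unreadable from compound 2 to compound 3. The estimate for compound 3 is 30000 nM, within 10000 nM to 100000 nM.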

Compound 3, half-maximal inhibitory concentration: 3350 nM
Compound 3: middle estimate off by 9.0-fold (0.95 log units), on the high side; the whole stated range lies above it.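

In this assay, compound 3 alone gives a readable number, while the other two compounds stay at a shared limit: the limit of > 20000 nM in this assay, at which 2 of the 3 values shown sit.

Chloro in place of methyl on an aromatic carbon gives an at least 5.9-fold lower number from compound 1 to compound 3 (0.77 log units; beyond the scatter). 2-Chlorophenyl in place of 3-methylphenyl on the amine nitrogen gives an at least 5.9-fold lower number from compound 2 to compound 3 (0.77 log units; beyond the scatter), so the aryl group at this place can move the read-out off the limit.

From the compounds shown here alone, both sizes are lower bounds, so the full size of each step stays open. Going by these compounds, whether bromo or methoxy in place of the chloro would keep the number of compound 3 also stays open.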